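This account rests on a few compounds, and the source may have more. Where it says the series, first, only, none or still open, it means among the compounds named here.

Measured so far in an assay on CHO cells for displacement of a labelled ligand from Orexin/Hypocretin receptor type 1 (Homo sapiens); on this read-out lower numbers stand for stronger inhibition and higher numbers for weaker inhibition:
compound 1 `COc1ccccc1-c1ccccc1NC(=O)[C@@H]1CCCN1C(=O)CCc1nc2ccccc2[nH]1`: 86 nM
compound 2 `O=C(Nc1ccccc1-n1cccc1)[C@@H]1CCCN1C(=O)CSc1nc2ccccc2s1`: 39 nM
compound 3 `Cc1ccc2c(c1)nc(SCC(=O)N1CCC[C@H]1C(=O)Nc1ccccc1-n1cccc1)n2C`: 0.7 nM

Compound 2 holds the second highest number of the three: compound 1 gives a somewhat higher number in this assay, while compound 3 lies far below it.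

Compound 4 `O=C(Nc1ccccc1-n1cccc1)[C@@H]1CCCN1C(=O)CCc1nc2ccccc2[nH]1` has not yet been measured. It differs from compound 2 in one place: (1H-benzimidazol-2-yl)methyl in place of (1,3-benzothiazol-2-yl)sulfanyl on a saturated chain carbon bound to a carbonyl carbon. The chain that enters is the same one found in compound 1, so compound 1 and compound 4 share this part and differ only in the amide portion of the shared core.

Among the measured compounds shown here, one measured step touches this change. Going a 56-fold lower number from compound 2 to compound 3 (1.75 log units; beyond the scatter) swapped a sulfur-linked benzothiazole for a sulfur-linked dimethylated benzimidazole, and the number fell sharply. Compound 4 also brings in a benzimidazole, but without the methyl groups and with a carbon chain instead of a sulfur link, so that step gives only a loose hint. Compound 1, carrying the same chain as compound 4, sits close to compound 2. Taken together, compound 4 is expected to land near compound 2, with a step of a 1.0-fold higher number from compound 2 to compound 4 (0.01 log units; within the scatter) that need not exceed the scatter. The estimate for compound 4 is 40 nM, with a range from 10 nM to 150 nM.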

Compound 4, inhibition constant: 130 nM
For compound 4 the middle estimate is 3.3-fold (0.51 log units) below the measured one; the measured number falls inside the stated range.
By their numbers in this assay, from the lowest: compound 3; then compound 2; then compounds 1 and 4 (each within the scatter of the next).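

In this assay, the step of a 3.3-fold higher number from compound 2 to compound 4 (0.52 log units; beyond the scatter) shows that at this place, on a saturated chain carbon bound to a carbonyl carbon, bringing in a benzimidazole does not by itself give the sharp fall seen in the step of a 56-fold lower number from compound 2 to compound 3 (1.75 log units; beyond the scatter); here the number moves the other way, by a modest amount. The step of a 1.5-fold higher number from compound 1 to compound 4 (0.18 log units; within the scatter) lies within the scatter, so with (1H-benzimidazol-2-yl)methyl on the chain, 1H-pyrrol-1-yl and 2-methoxyphenyl on an aromatic carbon cannot be told apart in this pair. The data shown offer no measurement that accounts for the rise from the benzothiazole-bearing group to the benzimidazole-bearing one.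

This change swaps the ring system and the link together, so the compounds shown leave open how much of the step belongs to the benzimidazole and how much to the carbon chain that replaces the sulfur link. From the compounds shown here alone, a pair carrying (1H-benzimidazol-2-yl)sulfanyl at this place would pull those two parts apart, while the effect of a longer chain between the carbonyl carbon and the benzimidazole also remains unknown.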